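Adding a Fluoro to Compound 3

This account rests on a few compounds, and the source may have more. Where it says the series, first, only, none or still open, it means among the compounds named here.

Of the compounds shown here, three sharing one core have been measured in a functional assay on MCF7 cells (Homo sapiens) for cytotoxicity, read by MTT assay, with a stated time of 96 h; on this read-out lower numbers stand for stronger inhibition and higher numbers for weaker inhibition: compound 1 `COc1cc(C(=O)c2cn(-c3ccccc3)cc2-c2ccc(N)cc2)cc(OC)c1OC` gives 9 nM, compound 2 `COc1cc(C(=O)c2cn(-c3ccccc3)cc2-c2ccc(Cl)cc2)cc(OC)c1OC` gives 290 nM, and compound 3 `COc1cc(C(=O)c2cn(-c3ccccc3)cc2-c2cccc([N+](=O)[O-])c2)cc(OC)c1OC` gives 50 nM. Compound 3 has the second highest number of the three, and it lies beyond the scatter from both others. The next compound, compound 4 `COc1cc(C(=O)c2cn(-c3ccc(F)cc3)cc2-c2cccc([N+](=O)[O-])c2)cc(OC)c1OC`, differs from compound 3 in one place, fluoro in place of hydrogen on an aromatic carbon, para to a large group, so that phenyl becomes 4-fluorophenyl.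

Among the compounds with values here, no measured step tests this change directly. All three compounds carry the plain phenyl, and their differences lie in the other aryl group. The step of a 32-fold higher number from compound 1 to compound 2 (1.51 log units; beyond the scatter) was large, while those of a 5.6-fold higher number from compound 1 to compound 3 (0.74 log units; beyond the scatter) and a 5.8-fold lower number from compound 2 to compound 3 (0.76 log units; beyond the scatter) were modest. These steps show only that this series can respond strongly to a substituent change elsewhere, so they give no direction for the fluoro. With so little evidence, a small step in this assay is expected, most likely within the scatter, though a modest move either way remains possible. The expected step is a 1.2-fold higher number from compound 3 to compound 4 (0.08 log units; within the scatter). For compound 4 the estimate is 60 nM, with an expected range from 20 nM to 180 nM.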

Compound 4, half-maximal inhibitory concentration: 440 nM
Compound 4: middle estimate off by 7.3-fold (0.87 log units), on the low side; the measured number lies above the stated range.
By their numbers in this assay, from the lowest: compound 1; then compound 3; then compounds 2 and 4 (each within the scatter of the next).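

The fluoro shows that the phenyl position, which stayed plain in compounds 1, 2 and 3, also affects the read-out in this assay: the change gives an 8.8-fold higher number from compound 3 to compound 4 (0.94 log units; beyond the scatter). The earlier steps shown here came only from changing the other aryl group, whereas here a single fluorine atom on an aromatic carbon, para to a large group, produces a step beyond the scatter and in the direction of weaker inhibition. Nothing available bears on why this one-atom change has such an effect.

The compounds shown leave open whether this loss belongs to fluoro in particular or would also follow from another group at the same place, such as chloro, methyl or methoxy, and whether a group like hydroxy or an amine would move the number the other way. They also leave open whether the change from phenyl to 4-fluorophenyl would give a step of similar size and direction on compound 1, which carries the 4-aminophenyl group, or on compound 2, which carries the 4-chlorophenyl group.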